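Replacing the 2-Oxopiperidin-1-yl Group: An Expected Half-Life

This account rests on a few compounds, and the source may have more. Where it says the series, first, only, none or still open, it means among the compounds named here.

Compound 1, `CCn1ncc2c(F)cc(-c3ccc(C(CC)(CC)c4nnc[nH]4)c(=O)[nH]3)cc21`: in an ADME assay on microsomes from liver (Rattus norvegicus) for metabolic stability (on this read-out lower numbers stand for a shorter-lived compound and higher numbers for a longer-lived compound), compound 1 reaches the assay limit > 3 h.
Compound 2, `CCn1ncc2c(F)cc(-c3ccc(C(CC)(CC)c4nnc(C)[nH]4)c(=O)[nH]3)cc21`: in this assay compound 2 also reaches the assay limit > 3 h.
Compound 3, `CC(C)C(c1ccc(-c2ccc3cccc(F)c3c2)[nH]c1=O)N1CCCCC1=O`: in this assay compound 3 gives 0.102 h.

Two of the three values therefore sit at a limit rather than a number, namely (the limit of > 3 h in this assay, at which 2 of the 3 values shown sit). For the measured compounds named here, the only measured step, methyl in place of hydrogen on an aromatic carbon, is a step that the two limits leave unreadable from compound 1 to compound 2, so it tells nothing about size. Going by the values given here, compound 3 stands as the only real number in this assay, and its half-life is short.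

Compound 4, `CC(C)C(c1noc(=O)[nH]1)c1ccc(-c2ccc3cccc(F)c3c2)[nH]c1=O`, differs from compound 3 in one place: a group of 6 heavy atoms (2 carbon, 2 nitrogen, 2 oxygen; one five-membered aromatic ring with 3 hetero atoms) in place of a group of 7 heavy atoms (5 carbon, 1 nitrogen, 1 oxygen; one six-membered non-aromatic ring with 1 hetero atom), on a saturated chain carbon bound to an aromatic carbon and a saturated chain carbon. Among the compounds with values here, no measured step involves this kind of exchange, and the one step that exists concerns a different part of a different core. The expectation for compound 4 therefore rests on compound 3 alone and on the fact that the change is a large one, which leaves the direction open. A modest lengthening is expected, a step of a 2.9-fold higher number from compound 3 to compound 4 (0.47 log units; beyond the scatter). Compound 4 is estimated at 0.3 h, with a range from 0.08 h to 1.5 h in this assay.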

Compound 4, half-life: > 3 h
Compound 4: only a limit was reported; the forecaster's own chance of this, stated with the estimate: 15%; at least 10-fold (1.00 log units) between middle value and limit.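

For the compounds shown here, on the saturated chain carbon bound to an aromatic carbon and a saturated chain carbon, the five-membered aromatic ring with 3 hetero atoms in place of 2-oxopiperidin-1-yl gives, in this assay, an at least 29-fold higher number from compound 3 to compound 4 (1.46 log units; beyond the scatter), the first step in this set whose size can be read at all. This shows that the group at this one position can by itself move the half-life of this core from short to the top of the measurable range, which the unreadable step between the two earlier compounds could not show. The value of compound 4 (> 3 h) is a limit of the assay and not a number, so the step gives only the smallest possible size of the change, and most of the values shown now sit at that same limit: the limit of > 3 h in this assay, at which 3 of the 4 values shown sit.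

The ring type and the counts of hydrogen-bond donors and acceptors all change together in this single exchange, and the compounds shown do not separate them. On these data alone, whether a carboxylic acid, an open-chain amide or a simple amine on the same carbon would give a half-life closer to compound 3 or to compound 4 stays open.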